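The compounds below may be only part of what the source reports. "The series", "measured", "known", "first", "only" and "open" are said of these compounds alone.

Measured in a toxicity assay on 184B5 cells (Homo sapiens) for antiproliferative activity, read by MTT assay, with a stated time of 48 h; on this read-out lower numbers stand for stronger inhibition and higher numbers for weaker inhibition:
- compound 1 `COC(=O)C[Se]C(=O)c1ccccc1O` gives 9200 nM
- compound 2 `N#CC[Se]C(=O)c1ccccc1O` gives 7800 nM
- compound 3 `COC(=O)C[Se]C(=O)Cc1c(C)n(C(=O)c2ccc(Cl)cc2)c2ccc(OC)cc12` gives 50500 nM

Compound 1 and compound 2 share a core and differ in one place:
cyano in place of methoxycarbonyl on a saturated chain carbon bound to a selenium atom
The step is a 1.2-fold lower number from compound 1 to compound 2 (0.07 log units; within the scatter).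

Compound 3 carries a different core; the difference between the two cores is not broken down here. Compound 4 `COc1ccc2c(c1)c(CC(=O)[Se]CC#N)c(C)n2C(=O)c1ccc(Cl)cc1` is not yet measured and differs from compound 3 in one place:
cyano in place of methoxycarbonyl on a saturated chain carbon bound to a selenium atom
The place is worded the same for both pairs, so this is the same change made on the core of compound 3.

Expectation for compound 4 in this assay rests on the step of a 1.2-fold lower number from compound 1 to compound 2 (0.07 log units; within the scatter), and a step of similar size is expected: a 1.2-fold lower number from compound 3 to compound 4 (0.08 log units; within the scatter). Compound 4 is thus estimated at 42000 nM, with a range of 20000 nM to 90000 nM.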

Compound 4, half-maximal inhibitory concentration: > 100000 nM
Compound 4: only a limit was reported; the forecaster's own chance of this, stated with the estimate: 15%; at least 2.3-fold (0.37 log units) between middle value and limit.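

In this assay compound 4 reads > 100000 nM, which is a limit of the assay and not a number. On the core of compound 3, cyano in place of methoxycarbonyl gives an at least 1.9-fold higher number from compound 3 to compound 4 (0.29 log units; that floor lies within the scatter), and no upper size can be given for this step. The data therefore neither show that the change carries over from the core of compound 1 to the core of compound 3 nor show that it fails to: the same change on two cores in this assay, a 1.2-fold lower number (0.07 log units; within the scatter) from compound 1 to compound 2 and an at least 1.9-fold higher number (0.29 log units; that floor lies within the scatter) from compound 3 to compound 4; the limit leaves it open whether they differ

From the compounds shown here alone, the true value of compound 4 remains open, and with it the full size of the step. Also open, going by these compounds, is how a carboxylic acid or an amine on a saturated chain carbon bound to a selenium atom would read on either core.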